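Amine variation at the side-chain end

The compounds below may be only part of what the source reports. "The series", "measured", "known", "first", "only" and "open" are said of these compounds alone.

- compound 1 (`CC(C)=CCc1cc(C(=O)Nc2cc3ccc(OCCC4CCCCN4)c(C)c3oc2=O)ccc1O`): 710 nM
- compound 2 (`CC(C)=CCc1cc(C(=O)Nc2cc3ccc(OCCCN4CCCC4)c(C)c3oc2=O)ccc1O`): 990 nM
- compound 3 (`CC(C)=CCc1cc(C(=O)Nc2cc3ccc(OCCCNC4CCCCC4)c(C)c3oc2=O)ccc1O`): 1070 nM

All three values come from a functional assay on MCF7 cells (Homo sapiens) for antiproliferative activity (on this read-out higher numbers stand for weaker inhibition and lower numbers for stronger inhibition), and compound 3 cannot be separated from the other two, with a 1.1-fold higher number from compound 2 to compound 3 (0.03 log units; within the scatter) and a 1.5-fold higher number from compound 1 to compound 3 (0.18 log units; within the scatter) as the steps leading to it. Compound 4 (`CC(C)=CCc1cc(C(=O)Nc2cc3ccc(OCCCN(C)c4ccccc4)c(C)c3oc2=O)ccc1O`) comes next, and the change is methyl(phenyl)amino in place of cyclohexylamino on a saturated chain carbon, three bonds along the chain from an oxygen on an aromatic ring on a saturated chain carbon, three bonds along the chain from an oxygen on an aromatic ring. Earlier replacements of the amine end group bear on it: a 1.4-fold higher number from compound 1 to compound 2 (0.14 log units; within the scatter) and a 1.1-fold higher number from compound 2 to compound 3 (0.03 log units; within the scatter) are the closest measured cases, and neither leaves the scatter. For the measured compounds named here, no measured compound carries methyl(phenyl)amino, so this evidence is indirect and the range stays wide. In this assay no step beyond the scatter is expected. The estimated change is small (a 1.1-fold lower number from compound 3 to compound 4 (0.03 log units; within the scatter)). For compound 4 the estimated value is 1000 nM with an expected range (450 nM to 2300 nM).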

Compound 4, half-maximal inhibitory concentration: > 50000 nM
Compound 4 was reported as a limit (the forecaster's own chance of this, stated with the estimate: 3%); middle value at least 50-fold (1.69 log units) away from the limit.
By their numbers in this assay, from the lowest: compounds 1, 2 and 3 (each within the scatter of the next). At a limit, above all of these: compound 4.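

The amine end group cannot be varied freely: the three earlier amines stay within the scatter of one another, yet methyl(phenyl)amino in place of cyclohexylamino gives an at least 46-fold higher number from compound 3 to compound 4 (1.66 log units; beyond the scatter) on the saturated chain carbon. Measured against the other two amines, the result is the same, with an at least 50-fold higher number from compound 2 to compound 4 (1.70 log units; beyond the scatter) and an at least 70-fold higher number from compound 1 to compound 4 (1.84 log units; beyond the scatter) in this assay as the remaining steps. Compound 4 is reported only as a limit, so all three steps are minimum sizes: the limit of > 50000 nM in this assay, at which 1 of the 4 values shown sits.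

This single change replaces a non-aromatic ring with an aromatic one and also removes the hydrogen-bond donor of cyclohexylamino, and the compounds shown do not separate these two differences. Phenylamino and methyl(cyclohexyl)amino end groups would show whether the aromatic ring or the methyl on the nitrogen accounts for the step.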